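Ester series: 2-(3-methoxyphenyl)ethenyl in place of furan-2-yl

A few compounds are considered here, and "the series" means these few. Any claim that something is new, unique, unknown or untested is made for them only; others in the source may bear on it.

Values in an ADME assay on HepG2 2.2.15 cells (Homo sapiens) for cytotoxicity (on this read-out lower numbers stand for higher toxicity in this test and higher numbers for lower toxicity in this test), for the series:
compound 1 `O=C(OCCc1c(-c2ccccc2Cl)c2cc(Cl)ccc2[nH]c1=O)C1CCCCC1` gives 38000 nM
compound 2 `CC(=O)N1CCC(C(=O)OCCc2c(-c3ccccc3Cl)c3cc(Cl)ccc3[nH]c2=O)CC1` gives 82000 nM
compound 3 `O=C(OCCc1c(-c2ccccc2Cl)c2cc(Cl)ccc2[nH]c1=O)c1ccco1` gives 98000 nM

Compound 3 at 98000 nM is not separated from its nearest neighbour, with a 1.2-fold higher number from compound 2 to compound 3 (0.08 log units; within the scatter) as the measured step, while a 2.6-fold higher number from compound 1 to compound 3 (0.41 log units; beyond the scatter) sets it apart from the furthest value. The next compound, compound 4 `COc1cccc(/C=C/C(=O)OCCc2c(-c3ccccc3Cl)c3cc(Cl)ccc3[nH]c2=O)c1`, carries 2-(3-methoxyphenyl)ethenyl in place of furan-2-yl on a carbonyl carbon as its change, 2-(3-methoxyphenyl)ethenyl in place of furan-2-yl on a carbonyl carbon.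

All measured steps swap the group at this same place. Two are modest, a 2.2-fold higher number from compound 1 to compound 2 (0.33 log units; beyond the scatter) and a 2.6-fold higher number from compound 1 to compound 3 (0.41 log units; beyond the scatter), and the third, a 1.2-fold higher number from compound 2 to compound 3 (0.08 log units; within the scatter), shows no separation. Among the compounds with values here, compound 1 at 38000 nM is the only measured compound with a ring of carbon only in this place, and it gives the lowest number. The entering group also holds a ring of carbon only, but one compound fixes no trend. A modest step toward a lower number is therefore expected in this assay, no larger than those measured. The estimated step is a 2.2-fold lower number from compound 3 to compound 4 (0.34 log units; beyond the scatter).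

Compound 4 is estimated at 45000 nM, with an expected range of 20000 nM to 100000 nM.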

Compound 4, half-maximal cytotoxic concentration: > 1300000 nM
Compound 4: no number, only a limit; the forecaster's own chance of this, stated with the estimate: 15%; middle value at least 28-fold (1.46 log units) away from the limit.
By their numbers in this assay, from the lowest: compound 1; then compounds 2 and 3 (each within the scatter of the next). At a limit, above all of these: compound 4.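

Compound 4 stands at a limit of the assay, not at a number, in this assay: the limit of > 1300000 nM in this assay, at which 1 of the 4 values shown sits. Replacing the group on this carbonyl carbon can therefore move the read-out much further than the earlier swaps showed, with an at least 13-fold higher number from compound 3 to compound 4 (1.12 log units; beyond the scatter), an at least 15-fold higher number from compound 2 to compound 4 (1.20 log units; beyond the scatter) and an at least 34-fold higher number from compound 1 to compound 4 (1.53 log units; beyond the scatter), all large. The earlier hint about a ring of carbon only does not hold as a pattern, as compound 1 has the lowest number in the series while compound 4, which also holds such a ring, sits at the limit.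

The true size of these steps stays unresolved, as only their lower ends are known. Also open, going by these compounds, is whether the change follows the ethenyl link, the aromatic ring or the methoxy group, and what an amine or a carboxylic acid in this place would give.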